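Amide series: phenyl for methyl on the ring nitrogen

The compounds below may be only part of what the source reports. "The series", "measured", "known", "first", "only" and "open" are said of these compounds alone.

Three compounds of the shared core have numbers in a functional assay, with a stated time of 20 min, tested at 0.1 mM; a lower number here means a weaker effect, a higher number a stronger effect of the compound at the concentration tested. Compound 1 `COC(=O)c1c(O)c2ccccc2n(-c2ccccc2)c1=O` gives 9.1%, compound 2 `NCCNC(=O)c1c(O)c2ccccc2n(-c2ccccc2)c1=O` gives 7.2%, and compound 3 `Cn1c(=O)c(C(=O)Nc2ccccc2N)c(O)c2ccccc21` gives 6%. Among the compounds with values here, the only counted step, a number 1.9 percentage points lower from compound 1 to compound 2 (within the scatter), lies within the scatter. Compound 3 holds the lowest of the three numbers, yet its gaps to compound 2 and to compound 1 are both within the scatter, so no order among the three can be read.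

Compound 4 `Nc1ccccc1NC(=O)c1c(O)c2ccccc2n(-c2ccccc2)c1=O` differs from compound 3 by phenyl in place of methyl on an aromatic nitrogen. Within the data shown here, no measured step covers this change; compounds 1 and 2, which carry phenyl on that aromatic nitrogen, sit in the same low band as compound 3. For compound 4 the expected step of a number 2 percentage points higher from compound 3 to compound 4 (within the scatter) is therefore none beyond the scatter. The estimate for compound 4 in this assay is 8%, with a range from 2% to 16%.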

Compound 4, a percentage reported as activity, at one concentration (the size of the read-out at that concentration, not a potency): 9.4%
Beside the measured number, compound 4's estimate is 1.4 percentage points below it, within the range that was stated.
By their numbers in this assay, from the lowest: compounds 3, 2, 1 and 4 (each within the scatter of the next).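

In this assay, within the data shown here, phenyl in place of methyl on an aromatic nitrogen gives a number 3.4 percentage points higher from compound 3 to compound 4 (within the scatter) and supplies the only measured step at this position, which lies within the scatter. On the carbonyl carbon, compound 4 also stays within the scatter of both neighbours: 2-aminophenyl in place of 2-aminoethyl gives a number 2.2 percentage points higher from compound 2 to compound 4 (within the scatter) and (2-aminophenyl)amino in place of methoxy gives a number 0.3 percentage points higher from compound 1 to compound 4 (within the scatter) as the closest step. No supporting data bear on this result.

Open, from the compounds shown here alone, is whether a benzyl group or a longer alkyl chain on that aromatic nitrogen would step beyond the scatter. Also open, going by these compounds, is whether a carboxylic acid on the carbonyl carbon would separate from these four compounds.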